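The compounds below may be only part of what the source reports. "The series", "measured", "known", "first", "only" and "open" are said of these compounds alone.

Three compounds have so far been tested in an ADME assay on Vero cells (Chlorocebus sabaeus) for cytotoxicity, read by neutral red uptake, tested at 49 ug/mL; on this read-out lower numbers stand for a stronger effect and higher numbers for a weaker effect at the one concentration tested:

Compound 1, `COc1ccc(C2SCC(=O)N2CCN2CCCCC2)cc1`, gives 100%.
Compound 2, `O=C1CSC(c2ccc(F)cc2)N1CCN1CCCCC1`, gives 100%.
Compound 3, `O=C1CSC(c2cccc(F)c2)N1CCN1CCCCC1`, gives 97%.

All three share the same core and differ only in the aromatic ring attached to it. Going from compound 2 to compound 1, the change is methoxy in place of fluoro on an aromatic carbon, and in this assay no change at the digits printed from compound 2 to compound 1 (within the scatter). Going from compound 2 to compound 3, the two have the same atoms joined differently: 3-fluorophenyl in place of 4-fluorophenyl on a saturated ring carbon, and in this assay a number 3 percentage points lower from compound 2 to compound 3 (within the scatter). All three read-outs therefore lie within the usual scatter of one another, and none of the three can be called stronger or weaker than the others.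

Compound 4, `COc1cccc(C2SCC(=O)N2CCN2CCCCC2)c1`, has not yet been measured. It differs from compound 3 by methoxy in place of fluoro on an aromatic carbon. Within the data shown here, this is the same kind of change as the one from compound 2 to compound 1, though not the same change: there the methoxy entered para to a large group, here it enters meta to a large group. Because no change at the digits printed from compound 2 to compound 1 (within the scatter), the estimated step for this second occurrence of the same kind of change is no change at the digits printed from compound 3 to compound 4 (within the scatter). Compound 4 is thus expected to give about 97% in this assay, most likely between 88% and 105%. Among the measured compounds shown here, the single earlier step is the only basis for this expectation, and it comes from a different position on the ring.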

Compound 4, a percentage reported as activity, at one concentration (the size of the read-out at that concentration, not a potency): 90%
Compound 4: middle estimate off by 7 percentage points, on the high side, and the stated range covers the measured number.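

In this assay, methoxy in place of fluoro on an aromatic carbon now gives a number 7 percentage points lower from compound 3 to compound 4 (within the scatter), and this second case can be set beside the first: the same change on two cores in this assay, no change at the digits printed (within the scatter) from compound 2 to compound 1 and a number 7 percentage points lower (within the scatter) from compound 3 to compound 4, 7 percentage points apart, within the scatter of two such steps The two cases therefore agree as far as this read-out can tell, and on both cores the swap leaves the number within the usual scatter, so this is a modest sign that it can be carried from one of these cores to the other without a clear shift. It does not show that the step is the same size on both, or that it is truly zero, since neither step stands out from the scatter, and two pairs measured at one concentration cannot set a rule for other cores in the series.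

The compounds shown leave open whether a different group on the aromatic ring, such as a chloro, a hydroxyl, an amine or a carboxylic acid, would move the number beyond the scatter. They also leave open what a longer chain joining the two halves of the molecule would do, as every change shown so far is confined to the aromatic ring.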